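The source may hold more compounds than are shown below. What is called first, only, known or untested is meant among the compounds shown, and "the series" means these compounds.

Compound 2, with the structure `CN(CCNCc1cn(Cc2nc3ccccc3[nH]2)nn1)CCNc1ccnc2cc(Cl)ccc12`, is the weaker of the two measured compounds in a functional assay on NCI-H460 cells (Homo sapiens) for antiproliferative activity, read by sulforhodamine B assay, with a stated time of 72 h; a higher number here means a weaker inhibitor, a lower number a stronger inhibitor: compound 2 gives 120000 nM. Among the measured compounds shown here, compound 1, with the structure `CN(CCNCc1cn(Cc2ccccc2)nn1)CCNc1ccnc2cc(Cl)ccc12`, gives 32000 nM in this assay, and the only measured step, a 3.8-fold higher number from compound 1 to compound 2 (0.57 log units; beyond the scatter), comes from exchanging the group on a saturated chain carbon bound to an aromatic nitrogen. Compound 3, with the structure `CN(CCNCc1cn(CCC(=O)Nc2ccccn2)nn1)CCNc1ccnc2cc(Cl)ccc12`, has not yet been measured. It differs from compound 2 at that same place: ((pyridin-2-yl)carbamoyl)methyl in place of 1H-benzimidazol-2-yl on a saturated chain carbon bound to an aromatic nitrogen. For the measured compounds named here, no measured step covers this particular exchange; the single step from compound 1 to compound 2 only shows that a change at this position moves the number modestly and can move it in either direction. The most reasonable expectation is therefore a number near that of compound 2, with a wide range that reaches toward compound 1 on one side. On that basis compound 3 is expected to give 70000 nM, within the range 18000 nM to 280000 nM, which corresponds to an estimated step of a 1.7-fold lower number from compound 2 to compound 3 (0.23 log units; within the scatter).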

Compound 3, half-maximal inhibitory concentration: > 200000 nM
Compound 3: only a limit was reported; the forecaster's own chance of this, stated with the estimate: 15%; middle value at least 2.8-fold (0.45 log units) from the limit.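

Compound 3 stands at a limit of this assay, not at a measured number: the limit of > 200000 nM in this assay, at which 1 of the 3 values shown sits. The exchange at this place gives an at least 1.6-fold higher number from compound 2 to compound 3 (0.22 log units; that floor lies within the scatter), so this floor alone does not settle an order between the two groups, whereas the change from phenyl gives an at least 6.2-fold higher number from compound 1 to compound 3 (0.79 log units; beyond the scatter), which is clearly beyond the scatter. A second, quite different group in place of phenyl therefore also gives a higher number, which makes compound 1 the strongest of the three, with no compound shown going against this.

The entering ((pyridin-2-yl)carbamoyl)methyl group differs from 1H-benzimidazol-2-yl in both its ring and its chain, and the compounds shown cannot separate these two parts or tell how far beyond the limit the true number of compound 3 lies. Also open, on these data alone, is whether a plain methyl group, or an amine or a carboxylic acid on a short chain, on a saturated chain carbon bound to an aromatic nitrogen would bring the number below that of compound 1.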